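Capping the free acid oxygen with butyl

The source may hold more compounds than are shown below. What is called first, only, known or untested is meant among the compounds shown, and "the series" means these compounds.

In a functional assay on HEL 299 cells (Homo sapiens) (on this read-out lower numbers stand for stronger inhibition and higher numbers for weaker inhibition), compound 3 `O=C(O)c1nn([C@@H]2O[C@H](CO)[C@@H](O)[C@H]2O)cc1I` gives only a limit, > 300000 nM. Compound 1 `NC(=O)c1nn([C@@H]2O[C@H](CO)[C@@H](O)[C@H]2O)cc1I` also gives only a limit, > 300000 nM. Compound 2 `COC(=O)c1nn([C@@H]2O[C@H](CO)[C@@H](O)[C@H]2O)cc1I` gives a measured 4000 nM. Compound 4 `CCCCOC(=O)c1nn([C@@H]2O[C@H](CO)[C@@H](O)[C@H]2O)cc1I` is butyl in place of hydrogen on an oxygen next to a carbonyl group, with butyl in place of hydrogen on an oxygen next to a carbonyl group. The closest measured change is an at least 75-fold higher number from compound 2 to compound 3 (1.87 log units; beyond the scatter), where hydrogen replaces methyl on that same oxygen, so it is read here in reverse. an at least 75-fold lower number from compound 1 to compound 2 (1.87 log units; beyond the scatter) also favours methoxy on the carbonyl carbon. No butyl change has been measured, so the size carries over only loosely. The expected step is an at least 60-fold lower number from compound 3 to compound 4 (1.77 log units; beyond the scatter), a large move to a lower number. For compound 4 the estimated value is 5000 nM, with an expected range of 800 nM to 40000 nM.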

Compound 4, half-maximal inhibitory concentration: 40000 nM
Beside the measured number, compound 4's estimate is 8.0-fold (0.90 log units) below it; low and high end bracket the measured number.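

Butoxy on the carbonyl carbon still gives a readable value in this assay, which means that a measured value here is not tied to methoxy alone (an at least 7.5-fold lower number from compound 3 to compound 4 (0.87 log units; beyond the scatter); an at least 7.5-fold lower number from compound 1 to compound 4 (0.87 log units; beyond the scatter)). Both of those steps start from a limit and give only a minimum size: the limit of > 300000 nM in this assay, at which 2 of the 4 values shown sit. Chain length on this oxygen also counts, with butoxy weaker than methoxy (a 10-fold higher number from compound 2 to compound 4 (1.00 log units; beyond the scatter)).

On these data alone, whether the loss builds steadily from methoxy to butoxy stays open, with ethoxy and propoxy as the untested intermediates. A longer chain such as hexyloxy, or branched isopropoxy, would show how far the trend extends.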